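The source may report more compounds than this note shows. Statements on the series, on what has been measured and on what is new or still open speak of the compounds shown alone.

Measured in a functional assay on cells (leukaemia cell line, Homo sapiens) for inhibition, read by sulforhodamine B assay, with a stated time of 48 h; on this read-out higher numbers stand for weaker inhibition of growth and lower numbers for stronger inhibition of growth:
compound 1 `O=S(=O)(Nc1ccc(Cl)c(F)c1)c1ccc(-c2cnc(C3CC3)o2)cc1` gives 63000 nM
compound 2 `O=S(=O)(Nc1cc(F)cc(F)c1)c1ccc(-c2cnc(C3CC3)o2)cc1` gives 80000 nM
compound 3 `Cc1cc(Cl)ccc1NS(=O)(=O)c1ccc(-c2cnc(C3CC3)o2)cc1` gives 54700 nM

Compound 3 is not separated from the other two compounds (a 1.2-fold lower number from compound 1 to compound 3 (0.06 log units; within the scatter) and a 1.5-fold lower number from compound 2 to compound 3 (0.17 log units; within the scatter)). Compound 4 `Cc1cc(Cl)cc(NS(=O)(=O)c2ccc(-c3cnc(C4CC4)o3)cc2)c1` differs from it only on the sulfonamide nitrogen (3-chloro-5-methylphenyl in place of 4-chloro-2-methylphenyl on a sulfonamide nitrogen). The measured steps that bear on this change are those two and a third at the same place (a 1.3-fold higher number from compound 1 to compound 2 (0.10 log units; within the scatter)), all within the scatter. Going by the values given here, no measured compound carries the 3-chloro-5-methylphenyl group, so this reading is indirect. No step beyond the scatter is expected in this assay (a 1.1-fold higher number from compound 3 to compound 4 (0.04 log units; within the scatter) is the expected step). For compound 4 the estimate is 60000 nM with an expected range from 32000 nM to 100000 nM in this read-out.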

Compound 4, concentration for total growth inhibition: 7040 nM
Compound 4: the middle estimate sits 8.5-fold (0.93 log units) above what was measured; measured number outside the range, below it.
By their numbers in this assay, from the lowest: compound 4; then compounds 3, 1 and 2 (each within the scatter of the next).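

In this assay, going by these compounds alone, the group on the sulfonamide nitrogen now matters: 3-chloro-5-methylphenyl gives a 7.8-fold lower number from compound 3 to compound 4 (0.89 log units; beyond the scatter) and an 8.9-fold lower number from compound 1 to compound 4 (0.95 log units; beyond the scatter) and an 11-fold lower number from compound 2 to compound 4 (1.06 log units; beyond the scatter) while the earlier steps at this place all stayed within the scatter. Compound 3 and compound 4 hold the same atoms, so a different arrangement of the chlorine and methyl on the ring is enough to separate them. Nothing measured here accounts for this step.

Still open, going by these compounds, is how much of the step depends on the chlorine and how much on the methyl of the 3-chloro-5-methylphenyl group. Also open, on these data alone, is whether an amine or a carboxylic acid in place of that methyl would keep the lower number.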